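Replacing a Carbamate Methoxy with an Aminophenyl Amide

The source may report more compounds than this note shows. Statements on the series, on what has been measured and on what is new or still open speak of the compounds shown alone.

Measured compounds:
Compound 1, `CCc1cc(S(=O)(=O)N2C[C@H](c3ccccc3)NC2=O)ccc1NC(=O)OC`, 300 nM
Compound 2, `CCOC(=O)Nc1ccc(S(=O)(=O)N2C[C@H](c3ccccc3)NC2=O)cc1F`, 4500 nM

Of the compounds shown here, two have been tested in a functional assay on NCI-H460 cells (Homo sapiens) for cytotoxicity, read by MTT assay; on this read-out higher numbers stand for weaker inhibition and lower numbers for stronger inhibition. Compound 1 gives 300 nM, the lower of the two numbers, while compound 2 gives 4500 nM, a gap that lies beyond the scatter of repeated measurements; since the two differ at more than one place, nothing further can be drawn from their comparison.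

The next compound in the series is compound 3, `CCc1cc(S(=O)(=O)N2C[C@H](c3ccccc3)NC2=O)ccc1NC(=O)c1ccc(N)cc1`. It keeps the shared core of compound 1 and alters only the group on the carbonyl carbon: 4-aminophenyl in place of methoxy on a carbonyl carbon. The methoxycarbonyl of compound 1 thus becomes a (4-aminophenyl)carbonyl.

For the measured compounds named here, no pair of measured compounds differing in one place is available, so the size and direction of this step cannot be read from the data. The expectation is a step of modest size in this assay, with no confident direction, so that the estimated change a 1.7-fold higher number from compound 1 to compound 3 (0.22 log units; within the scatter) is expected to stay near the scatter. Compound 3 is therefore estimated at 500 nM, within a range from 100 nM to 3000 nM.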

Compound 3, half-maximal inhibitory concentration: 670 nM
Compound 3: the middle estimate sits 1.3-fold (0.13 log units) below what was measured, within the range that was stated.
By their numbers in this assay, from the lowest: compound 1; then compound 3; then compound 2.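

For the compounds shown here, putting 4-aminophenyl in place of methoxy on the carbonyl carbon, read in this assay, gives a 2.2-fold higher number from compound 1 to compound 3 (0.35 log units; beyond the scatter), and this is the first comparison that isolates a single place. The step is modest although the entering group is much the larger of the two, with 7 heavy atoms and a six-membered aromatic ring against the 2 heavy atoms of methoxy, so the methoxycarbonyl of compound 1 is not needed for activity in this read-out, and compound 3 still gives 670 nM in this assay. There is no supporting measurement that explains why the number moves in this direction.

The compounds shown do not separate the effect of the aromatic ring from that of its amino group, so a plain phenyl or a 4-carboxyphenyl on the same carbonyl carbon would be needed to tell the two apart. They also leave open whether a short alkyl chain such as methyl or ethyl on that carbonyl carbon, with no ring at all, would sit closer to compound 1 or to compound 3.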